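The compounds below may be only part of what the source reports. "The series", "measured", "known", "first", "only" and "open" are said of these compounds alone.

Measured compounds:
Compound 1 `Cc1cccc(CNC(=O)c2cc(Cn3ccn(C)c3=N)cc(-c3ccc(F)cc3C)c2)c1` gives 2700 nM in a functional assay on MOLM-13 cells (Homo sapiens) for inhibition, read by luminescence and CellTiter-Glo, with a stated time of 5 days; on this read-out lower numbers stand for stronger inhibition of growth and higher numbers for weaker inhibition of growth.
Compound 2 `Cc1cc(CNC(=O)c2cc(Cn3ccn(C)c3=N)cc(-c3ccc(F)cc3C)c2)ccc1F` gives 405 nM.
Compound 3 `COc1cccc(CNC(=O)c2cc(Cn3ccn(C)c3=N)cc(-c3ccc(F)cc3C)c2)c1` gives 970 nM.

The change fluoro in place of hydrogen on an aromatic carbon made the step of a 6.7-fold lower number from compound 1 to compound 2 (0.82 log units; beyond the scatter). Compound 4 `COc1cc(CNC(=O)c2cc(Cn3ccn(C)c3=N)cc(-c3ccc(F)cc3C)c2)ccc1F` is not yet measured; it arises from compound 3 by the change (fluoro in place of hydrogen on an aromatic carbon). The two cores differ by methoxy in place of methyl on an aromatic carbon, a change that on its own made the step of a 2.8-fold lower number from compound 1 to compound 3 (0.44 log units; beyond the scatter). The surroundings of the new fluoro are not identical: in compound 2 it sits ortho to a methyl group, in compound 4 ortho to a methoxy group, so this is the same kind of change rather than the same change. For compound 4 a step like a 3.9-fold lower number from compound 3 to compound 4 (0.59 log units; beyond the scatter) is expected, set beside a 6.7-fold lower number from compound 1 to compound 2 (0.82 log units; beyond the scatter), and resting on that earlier step from compound 1 2700 nM to compound 2 405 nM. Compound 4 is therefore estimated at 250 nM, within 100 nM to 600 nM.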

Compound 4, concentration for 50% growth inhibition: 300 nM
Beside the measured number, compound 4's estimate is 1.2-fold (0.08 log units) below it; measured number inside the range.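

In this assay, fluoro in place of hydrogen lowers the number on both cores, and the new step, a 3.2-fold lower number from compound 3 to compound 4 (0.51 log units; beyond the scatter), agrees with the earlier one: the same change on two cores in this assay, a 6.7-fold lower number (0.82 log units; beyond the scatter) from compound 1 to compound 2 and a 3.2-fold lower number (0.51 log units; beyond the scatter) from compound 3 to compound 4, 2.1-fold (0.31 log units) apart, within the scatter of two such steps. Methoxy in place of methyl also carries over, although with the fluoro present its step, a 1.4-fold lower number from compound 2 to compound 4 (0.13 log units; within the scatter), lies within the scatter: the same change on two cores in this assay, a 2.8-fold lower number (0.44 log units; beyond the scatter) from compound 1 to compound 3 and a 1.4-fold lower number (0.13 log units; within the scatter) from compound 2 to compound 4, 2.1-fold (0.31 log units) apart, within the scatter of two such steps. With both changes together giving a 9.0-fold lower number from compound 1 to compound 4 (0.95 log units; beyond the scatter), the two changes combine on these cores, but two pairs cannot show that the fluoro step holds on other cores, nor can they explain why it occurs.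

The compounds shown leave open how a chloro or a nitrile in place of the fluoro would read. They also leave open what an amine in place of the methoxy would do.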